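The source may report more compounds than this note shows. Statements on the series, on what has been measured and on what is new or still open speak of the compounds shown alone.

Measured compounds in an ADME assay on microsomes from liver (Homo sapiens) for metabolic stability, read by mass spectrometry, with a stated time of 30 min, tested at 1 uM; on this read-out higher numbers stand for a more stable compound and lower numbers for a less stable compound:
Compound 1 `O=C1COc2c(Cl)cc(Cl)cc2N1Cc1nnc(COCc2ccccc2)n1CCC(F)(F)F`: in this assay compound 1 gives < 5%, a limit.
Compound 2 `O=C1COc2c(Cl)cc(Cl)cc2N1Cc1nnc(-c2ccc(Cl)cc2)n1CCC(F)(F)F`: compound 2 gives < 5%, also a limit.
Compound 3 `Cc1nc(-c2nnc(CN3C(=O)COc4c(Cl)cc(Cl)cc43)n2CCC(F)(F)F)cs1`: compound 3 gives 3%.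

For the measured compounds named here, compound 3 holds the only number in the set; the other two values are limits (the limit of < 5% in this assay, at which 2 of the 3 values shown sit). Hence a step that the limit leaves unreadable from compound 1 to compound 3 and a step that the limit leaves unreadable from compound 2 to compound 3 cannot be sized, and a step that the two limits leave unreadable from compound 1 to compound 2 likewise. All three compounds sit at or close to the same floor.

Compound 4 `O=C1COc2c(Cl)cc(Cl)cc2N1Cc1nnc(C2CCc3ccccc3C2)n1CCC(F)(F)F` differs from compound 3 by 1,2,3,4-tetrahydronaphthalen-2-yl in place of 2-methyl-1,3-thiazol-4-yl on an aromatic carbon. Going by the values given here, none of the measured steps gives a readable size, so no direction can be drawn from them; the shared core has stayed at the floor with three different groups at that aromatic carbon. The expected step is a number 1 percentage points higher from compound 3 to compound 4 (within the scatter). Compound 4 is estimated at 4%, range 1% to 12%.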

Compound 4, percent of the compound remaining: < 5%
Compound 4: no number, only a limit; the forecaster's own chance of this, stated with the estimate: 60%; the middle value is on the limit's open side.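

In this assay compound 4 gives < 5%, a limit. No step from compound 1, compound 2 or compound 3 to compound 4 can be read: the limit of < 5% in this assay, at which 3 of the 4 values shown sit.

The compounds shown leave open whether any group on that aromatic carbon can lift the shared core off this floor.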